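The source may hold more compounds than are shown below. What is called first, only, known or untested is meant among the compounds shown, and "the series" means these compounds.

Measured so far in an in vivo ADME assay on the whole organism for pharmacokinetics, with Rattus norvegicus as the target; a higher number here means that a larger share of the oral dose reaches the circulation, a lower number that a smaller share of the oral dose reaches the circulation

Compound 1 `CC(C)c1onc(COc2c(Cl)cc(F)cc2Cl)c1COc1ccc(/C=C/c2cccc(C(=O)O)c2)c(Cl)c1` gives 1.9%
Compound 2 `CC(C)c1onc(-c2c(Cl)cncc2Cl)c1COc1ccc(/C=C/c2cccc(C(=O)O)c2)c(Cl)c1` gives 7.8%

Compound 2 (7.8%) cannot be told apart from compound 1 (1.9%), since the two values lie within the scatter of each other. Compound 3 `CC(C)c1onc(COc2c(Cl)cccc2Cl)c1COc1ccc(/C=C/c2cccc(C(=O)O)c2)c(Cl)c1` departs from compound 2 in one place ((2,6-dichlorophenoxy)methyl in place of 3,5-dichloropyridin-4-yl on an aromatic carbon), with (2,6-dichlorophenoxy)methyl in place of 3,5-dichloropyridin-4-yl on an aromatic carbon. Going by the values given here, only one measured step bears on this: the exchange between compound 1 and compound 2 (a number 5.9 percentage points higher from compound 1 to compound 2 (within the scatter)), which involved the same pyridinyl group and a close relative of the entering group. Run in reverse, that small step suggests a slight drift toward compound 1, but nothing beyond the scatter in this assay. The expected step is correspondingly small (a number 4.3 percentage points lower from compound 2 to compound 3 (within the scatter)). For compound 3 the estimated value is 3.5% (range 1% to 10%).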

Compound 3, oral bioavailability: 9.2%
Estimate against measurement, compound 3: 5.7 percentage points below; low and high end bracket the measured number.
By their numbers in this assay, from the lowest: compounds 1, 2 and 3 (each within the scatter of the next).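

In this assay the exchange of 3,5-dichloropyridin-4-yl for (2,6-dichlorophenoxy)methyl at this position, on the aromatic carbon next to the ring nitrogen, now has a direct reading (a number 1.4 percentage points higher from compound 2 to compound 3 (within the scatter)), so these two groups cannot be told apart here. The new compound also adds a second kind of change, hydrogen in place of fluoro on an aromatic carbon of the entering group (a number 7.3 percentage points higher from compound 1 to compound 3 (within the scatter)), and this too leaves the two compounds indistinguishable. No measured evidence is available to explain these readings.

The three compounds leave open whether any group at this position can move this assay beyond the scatter. An amine or a longer alkyl chain there, or an amide in place of the carboxylic acid on the far end of the core, remains an open question.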